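The source may report more compounds than this note shows. Statements on the series, on what has been measured and on what is new or still open speak of the compounds shown alone.

Compound 1 `Cc1ccc(-c2csc(NC(=O)COc3ccccc3)n2)cc1` was examined in a functional assay on MDA-MB-468 cells (Homo sapiens) for cytotoxicity, read by trypan blue exclusion, with a stated time of 48 h (a lower number here means a stronger inhibitor, a higher number a weaker inhibitor), where compound 1 gives 54500 nM. Among the three compounds measured, compound 1 stands second highest, with compound 2 `Cc1ccc(-c2csc(NC(=O)COc3ccc(Br)cc3)n2)cc1` giving 40100 nM and compound 3 `Cc1ccc(-c2csc(NC(=O)COc3ccccc3C(C)C)n2)cc1` giving 56800 nM; all three lie within the usual scatter of one another. The two steps from compound 1 are a 1.4-fold lower number from compound 1 to compound 2 (0.13 log units; within the scatter) and a 1.0-fold higher number from compound 1 to compound 3 (0.02 log units; within the scatter), both changes on the phenoxy ring and both inside the scatter.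

Compound 4 `O=C(COc1ccccc1)Nc1nc(-c2ccc(Cl)cc2)cs1` is not yet measured. It differs from compound 1 by chloro in place of methyl on an aromatic carbon, a change on the other aromatic ring, on an aromatic carbon of a six-membered aromatic ring of carbon only, para to a large group. No measured step touches this ring, so the shown steps bear on it only indirectly: two small substituent changes elsewhere left this assay unmoved. The step from compound 1 to compound 4 in this assay is therefore expected to be a 1.1-fold lower number from compound 1 to compound 4 (0.04 log units; within the scatter), no change beyond the scatter. Compound 4 is estimated to give 50000 nM, with a range from 25000 nM to 100000 nM.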

Compound 4, half-maximal inhibitory concentration: 44200 nM
For compound 4 the middle estimate is 1.1-fold (0.05 log units) above the measured one; the range from low to high includes it.
By their numbers in this assay, from the lowest: compounds 2, 4, 1 and 3 (each within the scatter of the next).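

Within the data shown here, the step on the 4-methylphenyl ring, a 1.2-fold lower number from compound 1 to compound 4 (0.09 log units; within the scatter), is the first to touch this ring, and it shows that in this assay chloro can stand in place of methyl on this aromatic carbon without a shift beyond the scatter. The earlier steps showed this only for the phenoxy ring, so all three changes now shown, on both aromatic rings, remain within the scatter. Nothing available accounts for this result or gives any property of the two groups as measured.

The compounds shown leave open whether an amine, a carboxylic acid or a longer chain on this aromatic carbon would move the number beyond the scatter. Among these compounds, with no step yet beyond it, they also do not show which part of the core of compound 1 the number depends on.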